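Methyl in place of chloro: working notes

The compounds below may be only part of what the source reports. "The series", "measured", "known", "first", "only" and "open" are said of these compounds alone.

Values so far in an ADME assay on microsomes from liver (Mus musculus) for metabolic stability, read by LC-MS, using NADPH, tested at 0.1 uM (a lower number here means that the compound disappears faster, a higher number that the compound lasts longer), for the measured compounds:
- compound 1 `C=CC(=O)Nc1ccc(-n2nc3c(=O)[nH]nc(N)c3c2-c2oc3ccc(Cl)cc3c2C)cc1` gives 0.483 h as its half-life
- compound 2 `Cc1c(-c2c3c(N)n[nH]c(=O)c3nn2-c2ccc(NC(=O)/C=C/CN(C)C)cc2)oc2ccc(Cl)cc12` gives 1.72 h as its half-life

Going by the values given here, compound 2 holds the higher of the two numbers, with a 3.6-fold higher number from compound 1 to compound 2 (0.55 log units; beyond the scatter) as the only measured step. Compound 3 `Cc1ccc2oc(-c3c4c(N)n[nH]c(=O)c4nn3-c3ccc(NC(=O)/C=C/CN(C)C)cc3)c(C)c2c1` differs from compound 2 by methyl in place of chloro on an aromatic carbon. Among the compounds with values here, the measured step changes a group on a carbonyl carbon, so it gives no direct size for this change, and no measured step covers this aromatic carbon. The expectation therefore starts from compound 2 at 1.72 h and assumes little movement. The estimated outcome in this assay is a 1.3-fold lower number from compound 2 to compound 3 (0.12 log units; within the scatter), a slightly lower number that stays within the scatter. Compound 3 is expected at 1.3 h on this estimate, with 0.55 h to 2.8 h as its likely range.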

Compound 3, half-life: 1.05 h
Compound 3: the middle estimate sits 1.2-fold (0.09 log units) above what was measured; the range from low to high includes it.
By their numbers in this assay, from the lowest: compound 1; then compounds 3 and 2 (each within the scatter of the next).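

In this assay, methyl in place of chloro on this aromatic carbon, meta to a fused ring and para to a fused ring, gives a step within the scatter (a 1.6-fold lower number from compound 2 to compound 3 (0.21 log units; within the scatter)). This pair therefore does not separate the two groups at this position, at least with 3-(dimethylamino)prop-1-en-1-yl on the carbonyl carbon. No supporting measurement bears on the reason for this result.

Open, going by these compounds, is whether a group of another kind on this aromatic carbon, such as methoxy, an amine or a carboxylic acid, would also stay within the scatter of compound 2. Also open, on these data alone, is whether methyl in place of chloro reads the same way with vinyl on the carbonyl carbon, the group carried by compound 1.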